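This account rests on a few compounds, and the source may have more. Where it says the series, first, only, none or still open, it means among the compounds named here.

- compound 1 `CN(C)CCCNc1c(C(=O)NCc2ccc(F)cc2)nc(Br)c2cccnc12`: 6000 nM
- compound 2 `O=C(NCc1ccc(F)cc1)c1nc(Br)c2cccnc2c1N1CCNCC1`: 10000 nM

In a functional assay on HT-29 cells (Homo sapiens) for cytotoxicity, read by MTT assay, with a stated time of 72 h (a higher number here means a weaker inhibitor, a lower number a stronger inhibitor), compound 2 gives 10000 nM, which stands within the scatter of compound 1, so neither can be ranked above the other. Compound 3 `CNCCCNc1c(C(=O)NCc2ccc(F)cc2)nc(Br)c2cccnc12` carries (3-(methylamino)propyl)amino in place of piperazin-1-yl on an aromatic carbon. Going by the values given here, only one measured step bears on this change: a 1.7-fold higher number from compound 1 to compound 2 (0.22 log units; within the scatter), where piperazin-1-yl replaced (3-(dimethylamino)propyl)amino. That step stayed within the scatter, so no step beyond the scatter is expected in this assay. The expected step is a 1.4-fold lower number from compound 2 to compound 3 (0.15 log units; within the scatter). For compound 3 the estimate is 7000 nM, with an expected range of 3000 nM to 15000 nM.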

Compound 3, half-maximal inhibitory concentration: > 10000 nM
Compound 3 was reported as a limit (the forecaster's own chance of this, stated with the estimate: 10%); middle value at least 1.4-fold (0.15 log units) away from the limit.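

Compound 3 is reported in this assay as > 10000 nM, which is a limit of the assay and not a number. Replacing the piperazin-1-yl ring with the open (3-(methylamino)propyl)amino chain on this aromatic carbon, para to a bromo group, gives a number no lower from compound 2 to compound 3 (the limit leaves the size open). With hydrogen in place of methyl on the amine nitrogen, the step is an at least 1.6-fold higher number from compound 1 to compound 3 (0.22 log units; that floor lies within the scatter), so no real loss can be claimed, though the limit leaves room for a larger one. On these data alone, whether a longer chain or a primary amine at the end of the propyl chain would give a lower number stays open.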